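The compounds below may be only part of what the source reports. "The series", "measured", "known", "first", "only" and "open" are said of these compounds alone.

Compound 1 `O=C(CCC1=CCN(CCCc2ccc(Br)cc2)C1=O)NO` carries a 4-bromophenyl group on a saturated chain. In a functional assay on PC-3 cells (Homo sapiens) for inhibition, read by sulforhodamine B assay (a lower number here means a stronger inhibitor of growth, a higher number a weaker inhibitor of growth), compound 1 gives 3480 nM. Its nearest neighbour, compound 2 `Cc1cccc(CCCN2CC=C(CCC(=O)NO)C2=O)c1`, gives 3480 nM in this assay, so the two stand level at the digits shown. Within the data shown here, the single measured step between them, no change at the digits printed from compound 1 to compound 2 (within the scatter), alters the substituted phenyl group without moving the result beyond the usual scatter.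

Compound 3 `CC(C)c1ccc(CCCN2CC=C(CCC(=O)NO)C2=O)cc1` has not yet been measured. It differs from compound 1 by isopropyl in place of bromo on an aromatic carbon. Among the measured compounds shown here, no measured step changes exactly this bromo, but the comparison no change at the digits printed from compound 1 to compound 2 (within the scatter) shows that altering the group on the phenyl ring left this assay unchanged, so a step no larger than the scatter is expected here, with no clear direction. Compound 3 is therefore estimated at 3500 nM, within 1500 nM to 8000 nM. This estimate corresponds to an expected 1.0-fold higher number from compound 1 to compound 3 (0.00 log units; within the scatter).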

Compound 3, concentration for 50% growth inhibition: 3480 nM
For compound 3 the middle estimate is 1.0-fold (0.00 log units) above the measured one; measured number inside the range.
By their numbers in this assay, from the lowest: compounds 1, 2 and 3 (each within the scatter of the next).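

In this assay, isopropyl in place of bromo gives no change at the digits printed from compound 1 to compound 3 (within the scatter). The earlier step replaced 4-bromophenyl with 3-methylphenyl, so it changed both the group and its place on the ring; this one keeps the place, on an aromatic carbon para to a large group, and changes only the group. Going from 1 heavy atom to 3 heavy atoms, neither with any hydrogen-bond donors or acceptors, leaves the reading level here, and no supporting data explain why.

An amine or a carboxylic acid at this place, either of which would bring in a charged or hydrogen-bonding group, remains untested among the compounds shown. So does a longer chain between the phenyl ring and the ring nitrogen, so how far this flat result extends stays open.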